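The compounds below may be only part of what the source reports. "The series", "measured", "known", "first", "only" and "open" are said of these compounds alone.

Working notes on the series in an ADME assay on cells (Splenocyte, Mus musculus, strain BALB/c) for cytotoxicity, read by MTT assay, tested at 1 ug/mL; on this read-out lower numbers stand for a weaker effect and higher numbers for a stronger effect at the one concentration tested.

Compound 1, `CCCCCCCCCCCCCCC(N)CO`, gives 15.1%. Compound 2, `CCCCCCCCCCCCCCC(CO)N(CC)CC`, gives 7.5%. The change between them is diethylamino in place of amino on a saturated chain carbon bound to two saturated chain carbons; its step is a number 7.6 percentage points lower from compound 1 to compound 2 (within the scatter). Compound 3, `CCCCCCCCCCCCCCC(CN)NC(=O)OC(C)(C)C`, gives 4.2%, the lowest of the three numbers; its gap to compound 2 lies within the scatter, while its gap to compound 1 lies beyond it. The difference between the core of compound 1 and the core of compound 3 is not broken down here.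

Compound 4, `CCCCCCCCCCCCCCC(CN(CC)CC)NC(=O)OC(C)(C)C`, remains to be measured. It differs from compound 3 by diethylamino in place of amino on a saturated chain carbon, two bonds along the chain from an amide-type nitrogen. This is the same kind of change as that from compound 1 to compound 2, not the same one: there the place was on a saturated chain carbon bound to two saturated chain carbons, here it is on a saturated chain carbon, two bonds along the chain from an amide-type nitrogen. Because the earlier step of a number 7.6 percentage points lower from compound 1 to compound 2 (within the scatter) stayed within the scatter, the step from compound 3 to compound 4 is expected to stay small as well. The expected step for compound 4 is a number 1.2 percentage points lower from compound 3 to compound 4 (within the scatter). Compound 4 is estimated at 3%, with a range from 0% to 10%.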

Compound 4, a percentage reported as activity, at one concentration (the size of the read-out at that concentration, not a potency): 6.5%
The estimate for compound 4 lay 3.5 percentage points below the measured number; the measured number falls inside the stated range.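

In this assay, diethylamino in place of amino on the core of compound 3 gives a number 2.3 percentage points higher from compound 3 to compound 4 (within the scatter). Set beside the earlier step on the core of compound 1, the change carries over without a readable difference between the two cores: the same change on two cores in this assay, a number 7.6 percentage points lower (within the scatter) from compound 1 to compound 2 and a number 2.3 percentage points higher (within the scatter) from compound 3 to compound 4, 9.9 percentage points apart, within the scatter of two such steps This shows only that the step stays within the scatter on both cores; it does not fix a size or direction for the change, and it does not show that the same would hold on a third core.

The compounds shown leave open how the read-out would respond at the same places to a dimethylamino group, a carboxylic acid or a shorter chain. Also open, as far as these compounds go, is what the read-out would do at other concentrations, as every number here is the size of an effect at one concentration and gives no potency.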